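Trimming the Side Chain of Compound 2

The source may hold more compounds than are shown below. What is called first, only, known or untested is meant among the compounds shown, and "the series" means these compounds.

In a functional assay on MCF7 cells (Homo sapiens) for antiproliferative activity, read by MTT assay, with a stated time of 24 h (a lower number here means a stronger inhibitor, a higher number a weaker inhibitor), compound 1 (`CCN(CC)CCNC(=O)C1CC(C(CC)(CC)c2ccc(C#CC(C)(C)O)c(C)c2)=CN1CC`) gives 3170 nM, and compound 2 (`CCCC(O)(C#Cc1ccc(C(CC)(CC)C2=CCC(C(=O)NCCN(CC)CC)N2CC)cc1C)CCC`) gives 1360 nM. Compound 2 thus holds the lower of the two numbers, by a gap beyond the usual scatter. Compound 3 (`CCN(CC)CCNC(=O)C1CC=C(C(CC)(CC)c2ccc(/C=C/C(C)(O)CC)c(C)c2)N1CC`) differs from compound 2 in one place: a group of 7 heavy atoms (6 carbon, 1 oxygen; no ring) in place of a group of 10 heavy atoms (9 carbon, 1 oxygen; no ring), on an aromatic carbon. Among the compounds with values here, no measured pair shows this kind of change, so the forecast is uncertain. A small move towards a higher number, meaning a weaker inhibitor, is expected, not clearly beyond the scatter: a 1.8-fold higher number from compound 2 to compound 3 (0.26 log units; within the scatter). For compound 3 the estimated value is 2500 nM, with an expected range from 1000 nM to 6000 nM.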

Compound 3, half-maximal inhibitory concentration: "not active" (no number reported)
No number was reported for compound 3, and the estimate cannot be compared.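

Within the data shown here, compound 3 is reported as "not active" without a number, so no step from compound 2 to compound 3 can be read. The compounds shown leave open whether the double bond or the smaller group matters more in this assay. Nothing shown explains this result.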